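Acetoxymethyl enone series: aryl swap at the chain terminus

A few compounds are considered here, and "the series" means these few. Any claim that something is new, unique, unknown or untested is made for them only; others in the source may bear on it.

Measured so far:
- compound 1 `CCC(/C=C(\COC(C)=O)C(=O)c1ccccc1)CC` gives 89000 nM in a functional assay on T47D cells (Homo sapiens) for inhibition, read by sulforhodamine B assay, with a stated time of 48 h; a lower number here means a stronger inhibitor of growth, a higher number a weaker inhibitor of growth
- compound 2 `CC(=O)OC/C(=C\c1ccc(F)cc1)C(=O)c1ccccc1` gives 14000 nM in this assay

Among the measured compounds shown here, compound 2 holds the lowest of the two numbers in this assay; its nearest neighbour is compound 1, and the only measured step, a 6.4-fold lower number from compound 1 to compound 2 (0.80 log units; beyond the scatter), lies beyond the scatter.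

Compound 3 `CC(=O)OC/C(=C\c1ccccc1Br)C(=O)c1ccccc1` is not yet measured. It differs from compound 2 by 2-bromophenyl in place of 4-fluorophenyl on a double-bonded chain carbon bound to a double-bonded chain carbon.

For the measured compounds named here, the one measured step, a 6.4-fold lower number from compound 1 to compound 2 (0.80 log units; beyond the scatter), exchanged an open-chain group for an aryl ring at this position. Going by the values given here, the step from compound 2 to compound 3 keeps an aryl ring and alters only which halogen sits on it and where; no measured pair in this set speaks to such a change. The expectation therefore rests on compound 2 alone, and the step is expected to be no change at the digits printed from compound 2 to compound 3 (within the scatter), with no confident direction beyond the scatter.

Compound 3 is estimated at 14000 nM in this assay, within a range of 5000 nM to 40000 nM.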

Compound 3, concentration for 50% growth inhibition: 17000 nM
Estimate against measurement, compound 3: 1.2-fold (0.08 log units) below, and the stated range covers the measured number.
By their numbers in this assay, from the lowest: compounds 2 and 3 (each within the scatter of the next); then compound 1.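

In this assay, 2-bromophenyl in place of 4-fluorophenyl on a double-bonded chain carbon bound to a double-bonded chain carbon gives a 1.2-fold higher number from compound 2 to compound 3 (0.08 log units; within the scatter), so this change of halogen and ring placement, made together, leaves the two compounds indistinguishable. The open-chain comparison now extends to a second aryl group, with a 5.2-fold lower number from compound 1 to compound 3 (0.72 log units; beyond the scatter), so the lower number relative to pentan-3-yl is no longer tied to 4-fluorophenyl alone; both aryl groups shown go the same way and neither goes against it. Nothing on hand gives a reason for either step.

The compounds shown do not separate the halogen from its placement, as bromine and fluorine each appear at only one ring position, so two opposing contributions cannot be told from the absence of any contribution. Going by these compounds, it also remains open whether the series would stay in this range with an unsubstituted phenyl at this place, or with a ring carrying an amine or a carboxylic acid, or with a longer chain in place of pentan-3-yl.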